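The compounds below may be only part of what the source reports. "The series", "measured", "known", "first", "only" and "open" are said of these compounds alone.

Three compounds that share one core and differ only in the aromatic group on an amine nitrogen in a ring have been measured in a functional assay on A549 cells (Homo sapiens) for antiproliferative activity, read by MTT assay, with a stated time of 72 h; on this read-out higher numbers stand for weaker inhibition and lower numbers for stronger inhibition. Compound 1 (`Nc1nc(N)c2cc(CSC(=S)N3CCN(c4ccc(O)cc4)CC3)ccc2n1`) gives 4210 nM, compound 2 (`Cc1ccc(N2CCN(C(=S)SCc3ccc4nc(N)nc(N)c4c3)CC2)cc1`) gives 2190 nM, and compound 3 (`Cc1ccc(N2CCN(C(=S)SCc3ccc4nc(N)nc(N)c4c3)CC2)c(C)c1`) gives 3000 nM. Compound 3 therefore stands within the scatter of both other compounds, and the three values form a single group.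

The unmeasured compound 4 (`Nc1nc(N)c2cc(CSC(=S)N3CCN(c4ccc(F)cc4)CC3)ccc2n1`) carries 4-fluorophenyl in place of 2,4-dimethylphenyl on an amine nitrogen in a ring. Among the measured compounds shown here, no measured step introduces fluorine, so the evidence is indirect and comes from changes to this same aromatic group. These are a 1.9-fold lower number from compound 1 to compound 2 (0.28 log units; within the scatter), a 1.4-fold higher number from compound 2 to compound 3 (0.14 log units; within the scatter) and, for the exchange of the whole group, a 1.4-fold lower number from compound 1 to compound 3 (0.15 log units; within the scatter). Since none of these steps leaves the scatter, no step beyond the scatter is expected in this assay, and no direction can be favoured. The expected change is a 1.1-fold lower number from compound 3 to compound 4 (0.03 log units; within the scatter). For compound 4 the estimated value is 2800 nM, with an expected range from 1300 nM to 6000 nM.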

Compound 4, half-maximal inhibitory concentration: 2040 nM
The estimate for compound 4 lay 1.4-fold (0.14 log units) above the measured number; the measured number falls inside the stated range.
By their numbers in this assay, from the lowest: compounds 4, 2, 3 and 1 (each within the scatter of the next, the first and the last beyond it).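

With 4-fluorophenyl on the amine nitrogen in the ring, this series in this assay gains its first step beyond the scatter: exchanging the hydroxy group for fluoro gives a 2.1-fold lower number from compound 1 to compound 4 (0.31 log units; beyond the scatter), a modest gap that the step to the methyl analogue, compound 2, did not reach. Fluoro and methyl at this aromatic carbon cannot be told apart, with a 1.1-fold lower number from compound 2 to compound 4 (0.03 log units; within the scatter), and exchanging the whole 2,4-dimethylphenyl group for 4-fluorophenyl also stays inside the scatter, with a 1.5-fold lower number from compound 3 to compound 4 (0.17 log units; within the scatter). The data offer no measured reason for any of these numbers.

The compounds shown leave open whether a plain phenyl, an amine or a carboxylic acid on this aromatic group would stay with compounds 2, 3 and 4 or move the number further from them. They also leave open whether the small gap between the hydroxy and fluoro compounds would hold on any cell line other than this one.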